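Removing the nitro group: from compound 3 to compound 4

The source may report more compounds than this note shows. Statements on the series, on what has been measured and on what is new or still open speak of the compounds shown alone.

Measured compounds in an ADME assay on L02 cells (Homo sapiens) for inhibition, read by MTT assay, with a stated time of 48 h, tested at 100 uM; a lower number here means less inhibition, a higher number more inhibition at the concentration tested (going by the name of the read-out):
compound 1 `Cc1ccccc1-c1nc(=O)ss1`, 18.6%
compound 2 `O=c1nc(-c2ccccc2[N+](=O)[O-])ss1`, 33%
compound 3 `O=c1oc(-c2ccc([N+](=O)[O-])cc2Cl)ns1`, 54.6%

Compound 3 stands highest of the three numbers; compound 2 lies a number 14.4 percentage points higher from compound 1 to compound 2 (beyond the scatter) above compound 1, while compound 3 lies further above both, beyond the scatter in each case. Compound 4 `O=c1oc(-c2ccccc2Cl)ns1` is not yet measured in this assay. It differs from compound 3 by hydrogen in place of nitro on an aromatic carbon.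

Going by the values given here, only one measured step bears on this change: compound 1 and compound 2 share one core, and the step of a number 14.4 percentage points higher from compound 1 to compound 2 (beyond the scatter) shows a modest rise when nitro enters in place of methyl. The step to compound 4 runs the other way, nitro leaving for hydrogen, on the core shared with compound 3. A modest fall beyond the scatter is therefore expected, the step being estimated at a number 14.6 percentage points lower from compound 3 to compound 4 (beyond the scatter). Compound 4 is expected to give about 40% in this assay, within a range from 25% to 55%.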

Compound 4, a percentage reported as inhibition, at one concentration (the size of the read-out at that concentration, not a potency): 20.6%
For compound 4 the middle estimate is 19.4 percentage points above the measured one; the whole stated range lies above it.
By their numbers in this assay, from the lowest: compounds 1 and 4 (each within the scatter of the next); then compound 2; then compound 3.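

In this assay, taking the nitro group off this aromatic carbon, meta to a chloro group and para to a group of 6 heavy atoms, and leaving hydrogen gives a number 34 percentage points lower from compound 3 to compound 4 (beyond the scatter) and so a large step. The earlier step of a number 14.4 percentage points higher from compound 1 to compound 2 (beyond the scatter) was modest, but there nitro replaced methyl on another core, so it did not show what happens when nitro gives way to hydrogen on this one. Nothing available accounts for the size of this step.

From the compounds shown here alone, whether any other group at this carbon, such as an amine or a carboxylic acid, would keep the higher number of compound 3 or fall towards that of compound 4 stays open. Also open, going by these compounds, is whether hydrogen in place of nitro would give a step of similar size on the core of compound 2.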